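A few compounds are considered here, and "the series" means these few. Any claim that something is new, unique, unknown or untested is made for them only; others in the source may bear on it.

Measured compounds:
- Compound 1 `C(=C/c1nn2c(C3CCCCC3)nnc2s1)\c1ccco1`: 72%
- Compound 2 `Fc1cccc(-c2nnc3sc(/C=C/c4ccco4)nn23)c1`: 29%

In an assay for inhibition of histone-lysine N-methyltransferase, H3 lysine-79 specific (Homo sapiens), read by scintillation counting, with stated times of 15 min and 60 min, tested at 100 uM, in the presence of a further agent that is not named here (on this read-out lower numbers stand for a weaker effect and higher numbers for a stronger effect at the one concentration tested), compound 1 gives 72%, and compound 2 gives 29%. Within the data shown here, compound 2 thus stands lowest of the two numbers measured so far; its nearest neighbour is compound 1, and the only step recorded, a number 43 percentage points lower from compound 1 to compound 2 (beyond the scatter), came with 3-fluorophenyl in place of cyclohexyl on an aromatic carbon.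

Compound 3 `C(=C/c1nn2c(-c3ccccc3)nnc2s1)\c1ccco1` has not yet been measured. It differs from compound 2 in one place: hydrogen in place of fluoro on an aromatic carbon. Cut one bond further out, the change reads 3-fluorophenyl to phenyl, so compound 3 keeps the six-membered aromatic ring of carbon only that compound 2 carries and loses only the fluoro.

Among the measured compounds shown here, no measured step speaks directly to removing a fluoro here. The step of a number 43 percentage points lower from compound 1 to compound 2 (beyond the scatter) shows that the large drop arrived together with the aromatic ring, which compound 3 retains, so most of that loss is expected to remain. For compound 3 the expected step is a number 9 percentage points higher from compound 2 to compound 3 (within the scatter), a modest rise at best, and its value is estimated at 38%, within a range from 15% to 65%.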

Compound 3, a percentage reported as inhibition, at one concentration (the size of the read-out at that concentration, not a potency): 81%
Compound 3: middle estimate off by 43 percentage points, on the low side; measured number above the stated range.
By their numbers in this assay, from the lowest: compound 2; then compounds 1 and 3 (each within the scatter of the next).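

In this assay, the step is a number 52 percentage points higher from compound 2 to compound 3 (beyond the scatter), so at this position the single fluoro on the phenyl ring goes with a large loss of the read-out, while the aromatic ring itself does not. The step of a number 9 percentage points higher from compound 1 to compound 3 (within the scatter) lies within the scatter. Phenyl in place of cyclohexyl does not by itself reproduce the earlier drop: with no fluoro present, these two rings cannot be told apart here. Nothing available explains why removing one fluorine atom has so large an effect on this read-out.

The compounds shown leave open whether this loss belongs to fluoro alone or would also come with another group in the same place on the phenyl ring, such as chloro, methyl, methoxy or an amine. They also leave open how much of a ring this position needs, since a small chain such as ethyl or a longer chain such as hexyl in place of the phenyl or cyclohexyl ring would test whether any ring is required at all.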